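This account rests on a few compounds, and the source may have more. Where it says the series, first, only, none or still open, it means among the compounds named here.

In a functional assay on MGC-803 cells (Homo sapiens) for antiproliferative activity, read by CellTiter-Glo, with a stated time of 72 h (on this read-out higher numbers stand for weaker inhibition and lower numbers for stronger inhibition), compound 3 (`Cc1ccc(-c2cc(/C=C/c3ccc(C(=O)NO)cc3)ccn2)c(F)c1`) stands lowest of the three measured numbers at 770 nM against compound 2 (`Cc1ccc(-c2cc(/C=C/c3ccc(C(=O)NO)cc3)ccn2)cc1`) at 1910 nM and compound 1 (`O=C(NO)c1ccc(/C=C/c2ccnc(-c3cccnc3)c2)cc1`) at 4550 nM in this series. Compound 4 (`O=C(NO)c1ccc(/C=C/c2ccncc2)cc1`) carries hydrogen in place of 2-fluoro-4-methylphenyl on an aromatic carbon. Among the compounds with values here, no measured step removes that substituent outright. The closest steps only exchange it (a 2.4-fold lower number from compound 1 to compound 2 (0.38 log units; beyond the scatter) and a 5.9-fold lower number from compound 1 to compound 3 (0.77 log units; beyond the scatter)) or add fluoro to it (a 2.5-fold lower number from compound 2 to compound 3 (0.39 log units; beyond the scatter)), and all are modest yet beyond the scatter. Within the data shown here, an upward step of moderate size is expected (a 6.5-fold higher number from compound 3 to compound 4 (0.81 log units; beyond the scatter)) in this assay although no measured compound lacks the substituent. The estimated value for compound 4 is 5000 nM (expected range 1500 nM to 20000 nM).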

Compound 4, half-maximal inhibitory concentration: 3930 nM
Compound 4: middle estimate off by 1.3-fold (0.10 log units), on the high side; low and high end bracket the measured number.
By their numbers in this assay, from the lowest: compound 3; then compound 2; then compounds 4 and 1 (each within the scatter of the next).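

At this place next to the ring nitrogen, hydrogen gives a higher number than either substituted phenyl group, with a 5.1-fold higher number from compound 3 to compound 4 (0.71 log units; beyond the scatter) for loss of 2-fluoro-4-methylphenyl and a 2.1-fold higher number from compound 2 to compound 4 (0.31 log units; beyond the scatter) for loss of 4-methylphenyl. Pyridin-3-yl offers no such gain over hydrogen, with a 1.2-fold lower number from compound 1 to compound 4 (0.06 log units; within the scatter) as the step. Nothing available explains this split between the aryl groups. Still open, from the compounds shown here alone, is whether a substituent here must be aromatic at all: cyclohexyl or a morpholine ring could show that. Also open, going by these compounds, is whether fluoro without the methyl group on the phenyl ring keeps the lower number.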